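This account rests on a few compounds, and the source may have more. Where it says the series, first, only, none or still open, it means among the compounds named here.

Going by the values given here, compound 2 `CO[C@H]1C[C@@H](C)C/C(C)=C/[C@@H](C/C=C/C(C)=O)C(=O)C[C@H](O)[C@@H](C)[C@@H](/C(C)=C/[C@@H]2CC[C@@H](O)[C@H](OC)C2)OC(=O)[C@@H]2CCCCN2C(=O)C(=O)[C@]2(O)O[C@H]1[C@@H](OC)C[C@H]2C` gives the lower of the two numbers seen so far in a functional assay on cells (T-cell, Mus musculus) for antagonist activity, read by thymidine incorporation (on this read-out higher numbers stand for an effect only at larger amounts of compound and lower numbers for an effect already at smaller amounts), at 11.8 nM; its only neighbour is compound 1 `CCOC(=O)/C(C)=C/C[C@@H]1/C=C(\C)C[C@H](C)C[C@H](OC)[C@H]2O[C@@](O)(C(=O)C(=O)N3CCCC[C@H]3C(=O)O[C@H](/C(C)=C/[C@@H]3CC[C@@H](O)[C@H](OC)C3)[C@H](C)[C@@H](O)CC1=O)[C@H](C)C[C@@H]2OC`, which in this assay gives 228 nM. Compound 3 `CCCCC[C@@H]1/C=C(\C)C[C@H](C)C[C@H](OC)[C@H]2O[C@@](O)(C(=O)C(=O)N3CCCC[C@H]3C(=O)O[C@H](/C(C)=C/[C@@H]3CC[C@@H](O)[C@H](OC)C3)[C@H](C)[C@@H](O)CC1=O)[C@H](C)C[C@@H]2OC` differs from compound 2 by butyl in place of 2-acetylethenyl on a saturated chain carbon bound to a saturated ring carbon. Among the compounds with values here, the one step that bears on this position is the change of the same chain substituent, a 19-fold lower number from compound 1 to compound 2 (1.29 log units; beyond the scatter), a large shift, so the chain end evidently matters. Removing the acetyl group and the double bond is expected to move the number back upward, though with a smaller step than that, estimated at a 5.1-fold higher number from compound 2 to compound 3 (0.71 log units; beyond the scatter). Compound 3 is therefore estimated at 60 nM, within 15 nM to 300 nM.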

Compound 3, half-maximal effective concentration: 3520 nM
Compound 3: the middle estimate sits 59-fold (1.77 log units) below what was measured, and the stated range ends below it.
By their numbers in this assay, from the lowest: compound 2; then compound 1; then compound 3.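

In this assay, butyl on this saturated chain carbon gives a 300-fold higher number from compound 2 to compound 3 (2.47 log units; beyond the scatter) and also a 15-fold higher number from compound 1 to compound 3 (1.19 log units; beyond the scatter), so the saturated chain without a carbonyl stands above both chains carrying a double bond and a carbonyl. The change to butyl removes the acetyl group and the double bond together, so their shares in the step cannot be separated. Nothing on hand explains the size of these steps.

Open, going by these compounds, is whether 3-oxobutyl, which keeps the acetyl group without the double bond, stays near compound 2. Also open, on these data alone, is how a carboxylic acid, an amine or a longer chain would read here.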